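The source may report more compounds than this note shows. Statements on the series, on what has been measured and on what is new or still open speak of the compounds shown alone.

Compound 1, `CC1=C(C(=O)Nc2ccc(F)cc2)C(c2ccc([N+](=O)[O-])cc2)N=C(SCc2ccccc2Cl)N1`: in a functional assay on the whole organism (artery, strain albino) with Rattus norvegicus as the target, with a stated time of 240 min, at a dose of 10 mg/kg by the oral route (a higher number here means more inhibition at the dose given (going by the name of the read-out), a lower number less inhibition), compound 1 gives 15.9%.
Compound 2, `CC1=C(C(=O)Nc2ccc(Br)cc2)C(c2ccc(Cl)cc2Cl)N=C(SCc2ccccc2Cl)N1`: in this assay compound 2 gives 28.7%.
Compound 3, `COc1ccc(C2N=C(SCc3ccccc3Cl)NC(C)=C2C(=O)Nc2ccc(Br)cc2)cc1`: in this assay compound 3 gives 15.4%.

Compound 3 sits at the bottom of these three numbers. Compound 1 lies within the scatter of it, so the two cannot be told apart, while compound 2 lies beyond the scatter above it, as the step of a number 13.3 percentage points lower from compound 2 to compound 3 (beyond the scatter) shows.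

Compound 4, `COc1ccc(C2N=C(SCc3ccc(Cl)cc3)NC(C)=C2C(=O)Nc2ccc(Br)cc2)cc1`, has not yet been measured. It differs from compound 3 in one place: 4-chlorophenyl in place of 2-chlorophenyl on a saturated chain carbon bound to a sulfur. Among the compounds with values here, the only measured step, a number 13.3 percentage points lower from compound 2 to compound 3 (beyond the scatter), concerns a different place, the group on the saturated ring carbon, and leaves the chlorobenzyl group on the sulfur untouched. Within the data shown here, no measured pair changes that group, so nothing here bears directly on the step at hand.

Among the measured compounds shown here, with no step to lean on, the plain expectation is that compound 4 stays near compound 3, and the estimated step of a number 0.6 percentage points higher from compound 3 to compound 4 (within the scatter) is expected to lie within the scatter in either direction. Compound 4 is therefore estimated to give about 16% in this assay, with the true value expected between 5% and 29%.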

Compound 4, a percentage reported as inhibition, in the whole organism at one dose (the size of the read-out at that dose, not a potency): 29.2%
Estimate against measurement, compound 4: 13.2 percentage points below; the whole stated range lies below it.
By their numbers in this assay, from the lowest: compounds 3 and 1 (each within the scatter of the next); then compounds 2 and 4 (each within the scatter of the next).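

In this assay, within the data shown here, putting 4-chlorophenyl in place of 2-chlorophenyl on a saturated chain carbon bound to a sulfur gives a number 13.8 percentage points higher from compound 3 to compound 4 (beyond the scatter), the first measured change at this position. The two groups have the same atoms and the same counts, and only the place of the chlorine on the ring differs, so this position responds to a change that leaves the composition of the compound untouched; until now, only the group on the saturated ring carbon had been shown to move the number. No measurement shown here gives a reason for this step.

On these data alone, this is a single pair, read at one dose, so it remains open whether the same change would give a similar step with another group on the saturated ring carbon, such as the 2,4-dichlorophenyl of compound 2, or with another group on the amide. Also open, as far as these compounds go, is what this position would give with a plain phenyl carrying no chlorine, or with an amine or a carboxylic acid on that ring.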